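A few compounds are considered here, and "the series" means these few. Any claim that something is new, unique, unknown or untested is made for them only; others in the source may bear on it.

Among the measured compounds shown here, in an ADME assay on CHO cells (Cricetulus griseus) for cytotoxicity, read by MTT assay (a lower number here means that less compound is tolerated, a higher number that more compound is tolerated), compound 2 (`CN1CCN(CC2CCN(c3nccc4[nH]c(-c5cccc(OC(F)(F)F)c5)nc34)CC2)CC1`) gives 950 nM, the lower of the two numbers measured so far, while compound 1 (`CN1CCN(C2CCN(c3nccc4[nH]c(-c5cccc(OC(F)(F)F)c5)nc34)CC2)CC1`) gives 3000 nM. For the measured compounds named here, the only measured step is a 3.2-fold lower number from compound 1 to compound 2 (0.50 log units; beyond the scatter), beyond the scatter, with (4-methylpiperazin-1-yl)methyl in place of 4-methylpiperazin-1-yl on a saturated ring carbon. Compound 3 (`CN1CCN(CC2CCN(c3nccc4[nH]c(-c5cccc(C(=O)N(C)C)c5)nc34)CC2)CC1`) keeps that side chain of compound 2 and changes another site instead, with dimethylcarbamoyl in place of trifluoromethoxy on an aromatic carbon, meta to a large group: dimethylcarbamoyl in place of trifluoromethoxy on an aromatic carbon. Going by the values given here, no measured step touches this site, so the earlier step serves only as a rough yardstick for size and says nothing firm about direction. A modest move towards a higher number is tentatively expected, and the estimated change is a 1.9-fold higher number from compound 2 to compound 3 (0.28 log units; within the scatter). For compound 3 the expected value is 1800 nM, with an estimated range of 600 nM to 6000 nM.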

Compound 3, half-maximal cytotoxic concentration: > 50000 nM
Compound 3 ended at the assay's limit; the forecaster's own chance of this, stated with the estimate: 10%; middle value at least 27-fold (1.44 log units) away from the limit.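

In this assay, the site on the aromatic carbon proves far more sensitive than the side chain: dimethylcarbamoyl in place of trifluoromethoxy gives an at least 52-fold higher number from compound 2 to compound 3 (1.72 log units; beyond the scatter), a larger step than a 3.2-fold lower number from compound 1 to compound 2 (0.50 log units; beyond the scatter). Among the compounds shown here, the entry for compound 3 is a limit of the assay and not a number: the limit of > 50000 nM in this assay, at which 1 of the 3 values shown sits. This is the first measured change at this site, and it shows that the side chain of compound 2 does not by itself fix how much compound the cells tolerate.

The compounds shown do not tell whether the step follows from the loss of trifluoromethoxy or the arrival of dimethylcarbamoyl, a question that a methoxy group, a nitrile or a primary carboxamide at this site could help to settle. They also leave open whether dimethylcarbamoyl would give a similar step alongside the 4-methylpiperazin-1-yl group of compound 1.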